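A few compounds are considered here, and "the series" means these few. Any claim that something is new, unique, unknown or untested is made for them only; others in the source may bear on it.

Compound 1 `Cc1cc(C(=O)O)nn1C(C)c1cc(Cl)ccc1OCc1ccccc1` carries a free carboxylic acid, and in a physicochemical assay for lipophilicity, at pH 7.4 (a higher number here means a more lipophilic compound, a lower number a more polar compound), compound 1 gives 1. Compound 2 `Cc1cc(C(N)=O)nn1Cc1cc(Cl)ccc1OCc1ccccc1` has a primary amide in place of the acid, and in this assay compound 2 gives 3.7. Compound 3 `Cc1cc(C(=O)NC(C)C)nn1Cc1cc(Cl)ccc1OCc1ccccc1` adds an isopropyl to the amide nitrogen of compound 2. In this assay compound 3 gives > 3.7, which is a limit of the assay and not a number. The step of a number no lower from compound 2 to compound 3 (the limit leaves the size open) is therefore known only as a direction, not as a size.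

Compound 4 `Cc1cc(C(=O)Nc2cccc(F)c2)nn1Cc1cc(Cl)ccc1OCc1ccccc1` has not yet been measured. Its difference from compound 3 is 3-fluorophenyl in place of isopropyl on an amide-type nitrogen. For the measured compounds named here, the one measured step that bears on this change is a number no lower from compound 2 to compound 3 (the limit leaves the size open), where carbon added to the amide nitrogen did not lower the value. Here a larger group enters, so no fall is expected. Because compound 3 already sits at the limit of > 3.7 in this assay, at which 1 of the 3 values shown sits, the same limit may well cover compound 4 too.

Compound 4 is expected to give 4.6, within 3.9 to 5.3. The expected step that the limit leaves unreadable from compound 3 to compound 4 is upward, though the assay may again report only a limit.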

Compound 4, distribution coefficient: 2.8
The estimate for compound 4 lay 1.80 log units above the measured number; measured number below the stated range.
By their numbers in this assay, from the lowest: compound 1; then compound 4; then compound 2.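

At the amide nitrogen, the identity of the entering group now proves to matter: 3-fluorophenyl in place of isopropyl gives a number at least 0.90 log units lower from compound 3 to compound 4 (beyond the scatter), although the entering group has 7 heavy atoms against 3. Measured against the primary amide, the same aromatic group gives a number 0.90 log units lower from compound 2 to compound 4 (beyond the scatter), while isopropyl at this nitrogen gave a number no lower from compound 2 to compound 3 (the limit leaves the size open), so these two groups do not act alike at this position. Added size alone therefore does not set the number in this assay, and compound 4, which carries the larger group, goes against any rule that more carbon here brings a higher value.

On these data alone, how far the fall reaches stays open, since the value of compound 3 is a limit of the assay and not a number: the limit of > 3.7 in this assay, at which 1 of the 4 values shown sits. The compounds shown also cannot separate the aromatic ring from its fluorine, and a plain phenyl or a cyclohexyl on the same nitrogen would be needed to tell which of the two goes with the lower number.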